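Methyl for hydrogen on a naphthol in an antiproliferative series

The source may report more compounds than this note shows. Statements on the series, on what has been measured and on what is new or still open speak of the compounds shown alone.

In a functional assay on Ehrlich cells (Mus musculus) for antiproliferative activity, read by trypan blue exclusion, with a stated time of 2 h, tested at 100 ug/mL (a higher number here means a stronger effect of the compound at the concentration tested, a lower number a weaker effect), the measured compounds give:
compound 1 `N#CC1=C(N)N(c2ccc(S(N)(=O)=O)cc2)C2=C(C(=O)CCC2)C1c1ccc(O)cc1`: 100%
compound 2 `COc1ccc(C2C(C#N)=C(N)N(c3ccc(S(N)(=O)=O)cc3)C3=C2C(=O)CCC3)cc1`: 100%
compound 3 `N#CC1=C(N)N(c2ccc(S(N)(=O)=O)cc2)C2=C(C(=O)CCC2)C1c1c(O)ccc2ccccc12`: 15%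

Compound 3 differs from compound 1 in its core by 2-hydroxynaphthalen-1-yl in place of 4-hydroxyphenyl on a saturated ring carbon. That difference made a step of a number 85 percentage points lower from compound 1 to compound 3 (beyond the scatter) and, against compound 2, of a number 85 percentage points lower from compound 2 to compound 3 (beyond the scatter); compound 3 thus stands lowest of the three in this assay.

The change from compound 1 to compound 2 is methyl in place of hydrogen on an oxygen on an aromatic ring, and it made a step of no change at the digits printed from compound 1 to compound 2 (within the scatter). Compound 4 `COc1ccc2ccccc2c1C1C(C#N)=C(N)N(c2ccc(S(N)(=O)=O)cc2)C2=C1C(=O)CCC2` arises from compound 3 by methyl in place of hydrogen on an oxygen on an aromatic ring, the same change at the same kind of place, now on the core of compound 3, whose cores differ as told above.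

On the core of compound 1 this change left the read-out unmoved, so the step from compound 3 to compound 4 is expected to be small as well, a number 3 percentage points higher from compound 3 to compound 4 (within the scatter), because no change at the digits printed from compound 1 to compound 2 (within the scatter). Going by the values given here, only one earlier instance supports this, and there the two compounds sat at the top of the scale. Compound 4 is therefore estimated at 18%, between 5% and 45%.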

Compound 4, a percentage reported as activity, at one concentration (the size of the read-out at that concentration, not a potency): 80%
Beside the measured number, compound 4's estimate is 62 percentage points below it, and the stated range ends below it.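

In this assay, methyl in place of hydrogen on an oxygen on an aromatic ring gave a number 65 percentage points higher from compound 3 to compound 4 (beyond the scatter), and the steps of a number 20 percentage points lower from compound 2 to compound 4 (beyond the scatter) and a number 20 percentage points lower from compound 1 to compound 4 (beyond the scatter) show that the 2-methoxynaphthalen-1-yl compound still stands short of both earlier compounds. The size of this change therefore did not carry from one core to the other: the same change on two cores in this assay, no change at the digits printed (within the scatter) from compound 1 to compound 2 and a number 65 percentage points higher (beyond the scatter) from compound 3 to compound 4, 65 percentage points apart, beyond the scatter of two such steps. The comparison rests on two pairs only and gives no cause for the gap, and since compound 1 stands at 100% and compound 2 at 100%, at the top of the scale, a rise on that core could not have shown in the read-out.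

The compounds shown leave open whether a longer chain on that oxygen, such as ethoxy, would follow methyl on the core of compound 3. They also leave open whether an amine in place of the hydroxy group would behave like either of the two groups compared here.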